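The compounds below may be only part of what the source reports. "The series", "measured", "known", "first", "only" and "open" are said of these compounds alone.

Compound 1 `CCCCN(CCCC)Cc1cn(CC(O)COCc2ccccc2)nn1` gives 6% in an assay on nucleic acid for inhibition of Nucleic Acid, read by fluorescence, tested at 100 uM; on this read-out lower numbers stand for less inhibition and higher numbers for more inhibition at the one concentration tested (going by the name of the read-out). Compound 3 `CN(Cc1cn(CC(O)COCc2ccccc2)nn1)CC1CCCCC1` gives 6%, and the step of no change at the digits printed from compound 1 to compound 3 (within the scatter) shows that the change at the amine leaves the read-out where it was. Compound 1 and compound 3 together stand lowest of the three numbers. Compound 2 `CN(CCCc1ccccc1)Cc1cn(C2CCCCC2OC(=O)COc2ccccc2)nn1` differs from compound 1 in several places at once. In this assay, among the measured compounds shown here, compound 2 gives 42%, a higher number beyond the scatter, but no single-point step connects compound 2 to compound 1, so its number says nothing about one change alone.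

Compound 4 `CCCCN(CCCC)Cc1cn(CC(O)COC(=O)c2ccccc2)nn1` carries the change (benzoyl in place of benzyl on an oxygen on a saturated carbon). For the measured compounds named here, no measured step touches this oxygen on the saturated carbon; the only step in hand, no change at the digits printed from compound 1 to compound 3 (within the scatter), lies elsewhere in the molecule and was flat. With nothing in the measured steps to suggest movement, the expected step of a number 2 percentage points higher from compound 1 to compound 4 (within the scatter) stays within the scatter. Compound 4 is accordingly estimated at 8%, with a range from 0% to 25%.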

Compound 4, a percentage reported as inhibition, at one concentration (the size of the read-out at that concentration, not a potency): 12%
Compound 4: middle estimate off by 4 percentage points, on the low side; measured number inside the range.
By their numbers in this assay, from the lowest: compounds 1, 3 and 4 (each within the scatter of the next); then compound 2.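

In this assay the step of a number 6 percentage points higher from compound 1 to compound 4 (within the scatter) belongs to benzoyl in place of benzyl on an oxygen on a saturated carbon, so this position now has a measured step of its own. The entering group brings a carbonyl and one hydrogen-bond acceptor, and for this pair that exchange stays inside the scatter, which makes this a second flat step on the shared core alongside the one at the amine. No measured evidence ties this result to any property of either group.

From the compounds shown here alone, a free hydroxyl on this oxygen, or an acetyl or a longer chain in place of benzoyl, remains open, as does the same change on the amine of compound 3. Among the compounds shown here, also open is which feature of compound 2 goes with its 42%, since no single-place step connects it to the others.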